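A Methyl Added Where the Assay Already Shows Nothing

The source may report more compounds than this note shows. Statements on the series, on what has been measured and on what is new or still open speak of the compounds shown alone.

Of the compounds shown here, three have been tested in a functional assay for inhibition, with Homo sapiens as the target; on this read-out lower numbers stand for stronger inhibition and higher numbers for weaker inhibition. Compound 1 `CCCc1nc(C)c2c(CC)nnc(SC)n12` is the starting point; in this assay compound 1 gives > 48000 nM, which is a limit of the assay rather than a measured number. Compound 2 `CC(C)c1ncn2c(S)nncc12` likewise reaches only a limit, with a value in this assay of > 48000 nM. Among the measured compounds shown here, compound 3 `CCCc1ncc2c(C)cnc(Nc3cc[nH]n3)n12` is the one compound with a number: in this assay compound 3 gives 39000 nM. Compound 1 therefore stands at the limit, a position it shares as noted here: the limit of > 48000 nM in this assay, at which 2 of the 3 values shown sit.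

Compound 4 `CCCc1nc(C)c2c(C(C)C)nnc(SC)n12` has not been measured. It differs from compound 1 in one place: methyl in place of hydrogen on a saturated chain carbon bound to an aromatic carbon and a saturated chain carbon; seen one bond further out, the change reads ethyl to isopropyl. For the measured compounds named here, no pair of measured compounds differs in exactly this way, so the size of the step rests on no measured case. Compound 3 differs from compound 1 in several places at once, so its number gives no guide for this single change.

The expected step is a step that the limit leaves unreadable from compound 1 to compound 4, which amounts to no movement beyond the scatter and no clear direction. Compound 4 is expected to give 50000 nM, within a range of 20000 nM to 150000 nM, and the assay is expected more often than not to report only a limit again.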

Compound 4, half-maximal inhibitory concentration: > 48000 nM
Compound 4 was reported as a limit; the forecaster's own chance of this, stated with the estimate: 75%; the middle value lies beyond the limit too.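

In this assay compound 4 gives > 48000 nM as a limit of the assay and not a number. Among the compounds shown here, compound 1 also stands at a limit, so no step from compound 1 to compound 4 can be read: the limit of > 48000 nM in this assay, at which 3 of the 4 values shown sit. The compounds shown leave open whether changing ethyl to isopropyl alters inhibition at all.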